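Replacing 2-hydroxyethyl with cyclopropyl on the shared core

A few compounds are considered here, and "the series" means these few. Any claim that something is new, unique, unknown or untested is made for them only; others in the source may bear on it.

Values so far in a physicochemical assay for solubility, measured as kinetic solubility (a higher number here means a more soluble compound, a lower number a less soluble compound), are:
compound 1 `CCn1cc2c(Oc3ccc(S(C)(=O)=O)cc3)cc(C(=O)Nc3cnc(C)cn3)cc2n1` gives 2100 nM
compound 2 `Cc1cnc(NC(=O)c2cc(Oc3ccc(S(C)(=O)=O)cc3)c3cn(CCO)nc3c2)cn1` gives 24400 nM

Of these two, compound 2 stands highest, with 24400 nM as its reading. The next compound is compound 3 `Cc1cnc(NC(=O)c2cc(Oc3ccc(S(C)(=O)=O)cc3)c3cn(C4CC4)nc3c2)cn1`, which has cyclopropyl in place of 2-hydroxyethyl on an aromatic nitrogen. For the measured compounds named here, one measured step bears on this change, and it is large: a 12-fold higher number from compound 1 to compound 2 (1.07 log units; beyond the scatter) came with hydroxy in place of hydrogen on a saturated chain carbon. Compound 3 carries no hydroxy. Because compound 1 without that hydroxy gives 2100 nM as its reading, a large step down is expected in this assay for compound 3. Going by the values given here, no cyclopropyl compound has been measured, so the size remains uncertain. Expressed as a step, the estimate is an 8.1-fold lower number from compound 2 to compound 3 (0.91 log units; beyond the scatter) and remains only an expectation. Compound 3 is estimated at 3000 nM with 1000 nM to 9000 nM as the expected range.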

Compound 3, solubility: 500 nM
For compound 3 the middle estimate is 6.0-fold (0.78 log units) above the measured one, and the stated range ends above it.
By their numbers in this assay, from the lowest: compound 3; then compound 1; then compound 2.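

Cyclopropyl in place of 2-hydroxyethyl on the aromatic nitrogen gives a 49-fold lower number from compound 2 to compound 3 (1.69 log units; beyond the scatter) in this assay, a larger step than the one that came with the hydroxy. The hydroxy is therefore not the only feature of this position that moves the reading: with no hydroxy on either side, cyclopropyl in place of ethyl still gives a 4.2-fold lower number from compound 1 to compound 3 (0.62 log units; beyond the scatter) on the shared core. The position thus distinguishes between two groups made only of carbon and hydrogen, as well as between groups with and without a hydroxy. Nothing available explains either step.

Going by these compounds, whether a hydroxy carried on a cyclopropyl ring would bring the reading back up remains open. So does whether an amine or a carboxylic acid on a longer chain at this nitrogen would match 2-hydroxyethyl.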